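Swapping chloro for fluoro on the pendant ring

The source may hold more compounds than are shown below. What is called first, only, known or untested is meant among the compounds shown, and "the series" means these compounds.

Compound 1 `O=S(=O)(c1cc(F)cc(F)c1)c1cnc2c(F)cccc2c1-c1cccc(Cl)c1` is measured in an ADME assay on microsomes from liver (Homo sapiens) for metabolic stability, tested at 2.5 uM (on this read-out higher numbers stand for fast clearance and lower numbers for slow clearance), where compound 1 gives 0.64 mL/min. Among the three measured compounds, compound 1 stands second highest. Its nearest neighbour is compound 2 `O=S(=O)(c1cccc(F)c1)c1cnc2c(F)cccc2c1-c1cccc(Cl)c1`, which gives 0.56 mL/min, a 1.1-fold lower number from compound 1 to compound 2 (0.06 log units; within the scatter). Furthest away is compound 3 `N#Cc1cccc(S(=O)(=O)c2cnc3c(F)cccc3c2-c2cccc(Cl)c2)c1`, which gives 1.11 mL/min, a 1.7-fold higher number from compound 1 to compound 3 (0.24 log units; within the scatter); the step of a 2.0-fold higher number from compound 2 to compound 3 (0.30 log units; within the scatter) is likewise within the scatter.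

Compound 4 `O=S(=O)(c1cc(F)cc(F)c1)c1cnc2c(F)cccc2c1-c1cccc(F)c1` differs from compound 1 by fluoro in place of chloro on an aromatic carbon. Going by the values given here, no measured step touches this position; the three steps known all sit on the sulfonyl aryl and all stay within the scatter. The expectation for compound 4 is therefore no step beyond the scatter, a 1.1-fold lower number from compound 1 to compound 4 (0.03 log units; within the scatter). Compound 4 is expected to give 0.6 mL/min, between 0.3 mL/min and 1.2 mL/min.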

Compound 4, intrinsic clearance in a liver preparation (reported as CLH), per the amount of preparation that the assay uses: 1.18 mL/min
Compound 4: the middle estimate sits 2.0-fold (0.29 log units) below what was measured; the measured number falls inside the stated range.
By their numbers in this assay, from the lowest: compounds 2, 1, 3 and 4 (each within the scatter of the next, the first and the last beyond it).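

Going by these compounds alone, this is the first look at the chloro position on the pendant ring, as all earlier steps sit on the sulfonyl aryl. In this assay, fluoro in place of chloro gives a step within the scatter (a 1.8-fold higher number from compound 1 to compound 4 (0.27 log units; within the scatter)), so this read-out does not tell these two halogens apart at this place. No evidence is available that would explain this result.

This single pair is all that speaks for the position. As far as these compounds go, how a larger group there, such as an amine, a carboxylic acid or a longer chain, would read remains open.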